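The source may report more compounds than this note shows. Statements on the series, on what has been measured and on what is new or still open speak of the compounds shown alone.

Three measured compounds share one core and differ only in the group carried on the sulfonyl sulfur. Compound 1 `Cc1ccc(S(=O)(=O)N(C)C(C)C)cc1C#Cc1cc(Cl)ccc1OCC(=O)O` carries an isopropyl(methyl)amino group there and gives 3.8 nM in an assay on CHO cells for displacement of a labelled ligand from prostaglandin D2 receptor 2 (Homo sapiens), read by scintillation counting; a lower number here means a stronger inhibitor, a higher number a weaker inhibitor. Compound 2 `Cc1ccc(S(=O)(=O)N(C)C)cc1C#Cc1cc(Cl)ccc1OCC(=O)O` carries a dimethylamino group and gives 5 nM in this assay. Compound 3 `CCN(CC)S(=O)(=O)c1ccc(C)c(C#Cc2cc(Cl)ccc2OCC(=O)O)c1` carries a diethylamino group and gives 3.4 nM in this assay. The steps among them are all small: a 1.3-fold higher number from compound 1 to compound 2 (0.12 log units; within the scatter), a 1.1-fold lower number from compound 1 to compound 3 (0.05 log units; within the scatter) and a 1.5-fold lower number from compound 2 to compound 3 (0.17 log units; within the scatter). Compound 3 therefore cannot be told apart from compounds 1 and 2 on these numbers, since its steps to both lie within the scatter.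

Compound 4 `Cc1ccc(S(C)(=O)=O)cc1C#Cc1cc(Cl)ccc1OCC(=O)O` takes the change a stage further: methyl in place of diethylamino on a sulfonyl sulfur. The measured steps bear on this only indirectly. They show that swapping one amino group for another on the sulfonyl sulfur makes no difference beyond the scatter, whereas here the nitrogen itself leaves. For compound 4 the expected step is a 2.4-fold higher number from compound 3 to compound 4 (0.37 log units; beyond the scatter), perhaps drifting toward a slightly higher number. The estimate for compound 4 in this assay is 8 nM, expected to fall between 2.5 nM and 25 nM.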

Compound 4, inhibition constant: 5 nM
Estimate against measurement, compound 4: 1.6-fold (0.20 log units) above, within the range that was stated.
By their numbers in this assay, from the lowest: compounds 3, 1, 2 and 4 (each within the scatter of the next).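

Methyl in place of an amino group on a sulfonyl sulfur removes the nitrogen altogether, yet in this assay the steps read a 1.5-fold higher number from compound 3 to compound 4 (0.17 log units; within the scatter) and no change at the digits printed from compound 2 to compound 4 (within the scatter) and also a 1.3-fold higher number from compound 1 to compound 4 (0.12 log units; within the scatter) in this series. The earlier compounds only exchanged one amino group for another, so they could not show that, among these four compounds, the sulfonyl sulfur needs no nitrogen for the number to stay within the scatter. No measured evidence is available to explain why these groups read alike.

The compounds shown leave open whether any group on the sulfonyl sulfur can move the number beyond the scatter, since a piperidine ring, a phenyl ring and a longer chain such as butyl appear in none of them. On these data alone, all four also keep the sulfonyl itself, so a carbonyl in its place remains untested here.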